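Replacing methanesulfonamido with methyl in compound 2

The source may report more compounds than this note shows. Statements on the series, on what has been measured and on what is new or still open speak of the compounds shown alone.

Compound 1 (`CC(C)CCn1c(Cn2c(=O)n(C(C)C)c3ccccc32)nc2cc(CN)ccc21`) gives 3920 nM
Compound 2 (`CC(C)CCn1c(Cn2c(=O)n(C(C)C)c3ccccc32)nc2cc(CNS(C)(=O)=O)ccc21`) gives 30800 nM

In an ADME assay on HEp-2 cells (Homo sapiens) for cytotoxicity (on this read-out higher numbers stand for lower toxicity in this test and lower numbers for higher toxicity in this test), compound 2 stands highest of the two measured compounds. Compound 3 (`CCc1ccc2c(c1)nc(Cn1c(=O)n(C(C)C)c3ccccc31)n2CCC(C)C`) differs from it by methyl in place of methanesulfonamido on a saturated chain carbon bound to an aromatic carbon with methyl in place of methanesulfonamido on a saturated chain carbon bound to an aromatic carbon. Going by the values given here, the only measured step bearing on this is a 7.9-fold higher number from compound 1 to compound 2 (0.90 log units; beyond the scatter) and it changed the same nitrogen-bearing group. Among the compounds with values here, no measured compound carries methyl there, so a smaller move toward a lower number is expected. The expected step is a 2.2-fold lower number from compound 2 to compound 3 (0.34 log units; beyond the scatter) in this assay on this estimate. Compound 3 is estimated at 14000 nM with an expected range of 4500 nM to 45000 nM in this read-out.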

Compound 3, half-maximal cytotoxic concentration: 18500 nM
Compound 3: the middle estimate sits 1.3-fold (0.12 log units) below what was measured, within the range that was stated.
By their numbers in this assay, from the lowest: compound 1; then compounds 3 and 2 (each within the scatter of the next).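

In this assay the exchange for methyl gives a 1.7-fold lower number from compound 2 to compound 3 (0.22 log units; within the scatter) and so methanesulfonamido can leave this saturated chain carbon without a step beyond the scatter. Methyl in place of amino gives a 4.7-fold higher number from compound 1 to compound 3 (0.67 log units; beyond the scatter) and so compound 1, the amine, alone stands apart among the three, with the lowest number. Nothing available gives a reason for this pattern.

From the compounds shown here alone, whether a carboxylic acid, a hydroxyl or a longer chain in this place would fall with compound 1 or with compounds 2 and 3 stays open.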